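The compounds below may be only part of what the source reports. "The series", "measured", "known", "first", "only" and "open" are said of these compounds alone.

Compound 1 `FC(F)(Cl)C(F)(Cl)CCSc1nc2ccc(Cl)cc2s1`: in a functional assay on SH-SY5Y cells (Homo sapiens) for cytotoxicity, read by MTT assay, with a stated time of 48 h (on this read-out lower numbers stand for stronger inhibition and higher numbers for weaker inhibition), compound 1 gives > 120000 nM, which is a limit of the assay. Compound 2 `N#CC(C#N)=Cc1nccs1`: in this assay compound 2 gives > 120000 nM, likewise a limit and not a number.

Compound 2 therefore stands at the limit of > 120000 nM in this assay, at which 2 of the 2 values shown sit, the level shared by every value shown. Compound 3 `CC(=C(C#N)C#N)c1nccs1` differs from compound 2 by methyl in place of hydrogen on a double-bonded chain carbon bound to an aromatic carbon and a double-bonded chain carbon. Among the measured compounds shown here, no step between measured compounds is available to size this change, and in this assay no movement beyond the scatter is expected in either direction. Compound 3 is expected to give 150000 nM, from 60000 nM to 500000 nM, the expected step being a step that the limit leaves unreadable from compound 2 to compound 3.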

Compound 3, half-maximal inhibitory concentration: 68800 nM
Estimate against measurement, compound 3: 2.2-fold (0.34 log units) above, and the stated range covers the measured number.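

Going by these compounds, at this position, methyl in place of hydrogen gives an at least 1.7-fold lower number from compound 2 to compound 3 (0.24 log units; that floor lies within the scatter) in this assay and so sets only a floor on the change, whose full size stays unknown. Compound 3 is the first compound shown with a measured number rather than a limit: the limit of > 120000 nM in this assay, at which 2 of the 3 values shown sit.

On these data alone, whether the true step from hydrogen to methyl lies beyond the scatter remains open. So does the question of how an ethyl group, a longer chain or an amine on the same double-bonded chain carbon would read in this assay at all.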